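The source may hold more compounds than are shown below. What is called first, only, known or untested is meant among the compounds shown, and "the series" means these compounds.

Three compounds sharing one core have been examined in a functional assay on CHO cells with adenosine receptor A1 (Homo sapiens) as the target, read by cAMP accumulation and immunoassay, with a stated time of 6 min, tested at 0.1 uM; on this read-out lower numbers stand for a stronger effect and higher numbers for a weaker effect at the one concentration tested. Compound 1 `Nc1scc(CN2CCN(c3cc(Cl)cc(Cl)c3)CC2)c1C(=O)c1ccc(Cl)cc1` gives -22%. Compound 2 `Nc1scc(CN2CCN(c3cccc4ccccc34)CC2)c1C(=O)c1ccc(Cl)cc1` gives 0%. Compound 3 `Nc1scc(CN2CCN(c3c(F)cccc3F)CC2)c1C(=O)c1ccc(Cl)cc1` gives -23%, the lowest of the three numbers, with compound 1 nearest to it and compound 2 furthest away. Compound 4 `Nc1scc(CN2CCN(c3cccc(F)c3F)CC2)c1C(=O)c1ccc(Cl)cc1` has not yet been measured; it differs from compound 3 by 2,3-difluorophenyl in place of 2,6-difluorophenyl on an amine nitrogen in a ring. Two measured steps exchange one aryl group for another on the same ring nitrogen and so bear on this change: a number 1 percentage points lower from compound 1 to compound 3 (within the scatter), which stays within the scatter, and a number 23 percentage points lower from compound 2 to compound 3 (beyond the scatter), a modest shift. For compound 4 the expected step is therefore a number 8 percentage points higher from compound 3 to compound 4 (within the scatter), small enough that it may well stay within the scatter. The estimate for compound 4 is -15%, with a range from -40% to 8%.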

Compound 4, a percentage reported as activity, at one concentration (the size of the read-out at that concentration, not a potency): -5.2%
Compound 4: the middle estimate sits 9.8 percentage points below what was measured, within the range that was stated.
By their numbers in this assay, from the lowest: compounds 3 and 1 (each within the scatter of the next); then compounds 4 and 2 (each within the scatter of the next).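

With the same atoms joined differently, 2,3-difluorophenyl in place of 2,6-difluorophenyl on the ring nitrogen gives a step beyond the scatter (a number 17.8 percentage points higher from compound 3 to compound 4 (beyond the scatter)), so at this position the arrangement of the two fluorines counts in this assay, not only the choice of aryl group. That step separates compound 4 from the 3,5-dichlorophenyl group as well (a number 16.8 percentage points higher from compound 1 to compound 4 (beyond the scatter)), but not from naphthalen-1-yl (a number 5.2 percentage points lower from compound 2 to compound 4 (within the scatter)). Nothing available explains this difference. From the compounds shown here alone, how a single fluorine, a methoxy group or a pyridine ring on that nitrogen would read remains open.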